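This account rests on a few compounds, and the source may have more. Where it says the series, first, only, none or still open, it means among the compounds named here.

Measured so far in a functional assay on MCF7 cells (Homo sapiens) for antiproliferative activity, read by sulforhodamine B assay, with a stated time of 48 h; on this read-out higher numbers stand for weaker inhibition and lower numbers for stronger inhibition:
- Compound 1 `CN1CCN(c2ccc(S(=O)(=O)Oc3cccc(F)c3)cc2)C1=O`: > 100000 nM (a limit of the assay, not a number)
- Compound 2 `CN1CCN(c2ccc(S(=O)(=O)Oc3cccc(I)c3)cc2)C1=O`: 560 nM

Among the measured compounds shown here, compound 2 holds the only true number so far, so it can be compared only with the limit reached by compound 1. Compound 3 `Cc1ccc(OS(=O)(=O)c2ccc(N3CCN(C)C3=O)cc2)cc1` has not yet been measured. It keeps the shared core but carries 4-methylphenyl in place of 3-iodophenyl on an oxygen.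

For the measured compounds named here, only one measured step bears on this change: an at least 170-fold lower number from compound 1 to compound 2 (2.25 log units; beyond the scatter), where iodo replaced fluoro on an aromatic carbon. That large step shows how much a single swap on this ring can matter in this assay. Going by the values given here, compound 3 has no iodine, and no measured compound carries a methyl, so weaker inhibition is expected, with wide uncertainty. The expected step is an 8.9-fold higher number from compound 2 to compound 3 (0.95 log units; beyond the scatter). Compound 3 is estimated at 5000 nM, within a range of 500 nM to 60000 nM.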

Compound 3, half-maximal inhibitory concentration: > 100000 nM
Compound 3: no number, only a limit; the forecaster's own chance of this, stated with the estimate: 20%; middle value at least 20-fold (1.30 log units) from the limit.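

In this assay, 4-methylphenyl in place of 3-iodophenyl on the oxygen gives an at least 170-fold higher number from compound 2 to compound 3 (2.25 log units; beyond the scatter), so the activity of compound 2 does not carry over to this second ring without iodine. Of the three aryl groups shown on this oxygen, only 3-iodophenyl gives a true number, which makes this place on the molecule look demanding, though three compounds are a small sample. Compound 1 and compound 3 both stop at a limit of the assay, so the step between them cannot be read: the limit of > 100000 nM in this assay, at which 2 of the 3 values shown sit.

This change alters both the group and where it sits on the ring, so the two effects remain unseparated; 3-methylphenyl or 4-iodophenyl would pull them apart. As far as these compounds go, whether iodine itself is required also stays open, and 3-bromophenyl or 3-chlorophenyl would address that.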